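The source may report more compounds than this note shows. Statements on the series, on what has been measured and on what is new or still open speak of the compounds shown alone.

Compounds measured so far:
compound 1 `C=C(Br)C(=O)Nc1ccc(/C=C2\SC(=O)N(Cc3cccc(Cl)c3)C2=O)cc1` gives 8900 nM;
compound 2 `Nc1ccc(/C=C2\SC(=O)N(Cc3cccc(F)c3)C2=O)cc1` gives 250000 nM;
compound 3 `Nc1ccc(/C=C2\SC(=O)N(Cc3cccc(Cl)c3)C2=O)cc1` gives 24000 nM.

In a functional assay on HeLa cells (Homo sapiens) for cytotoxicity, read by cell counting, with a stated time of 4 days (a higher number here means a weaker inhibitor, a lower number a stronger inhibitor), compound 1 stands lowest of the three numbers. Compound 3 lies nearest, with a 2.7-fold higher number from compound 1 to compound 3 (0.43 log units; beyond the scatter), and compound 2 furthest. Compound 4 `C=C(Br)C(=O)Nc1ccc(/C=C2\SC(=O)N(Cc3ccc(F)cc3)C2=O)cc1` differs from compound 1 by 4-fluorophenyl in place of 3-chlorophenyl on a saturated chain carbon bound to an amide-type nitrogen in a ring. Of the measured steps only the halogen swap bears on this change: a 10-fold lower number from compound 2 to compound 3 (1.02 log units; beyond the scatter), a large step. Compound 4 reverses that swap while also moving the halogen, so a higher number is expected, though the different placement leaves its size uncertain. For compound 4 the estimate is 45000 nM, between 12000 nM and 170000 nM, a step of a 5.1-fold higher number from compound 1 to compound 4 (0.70 log units; beyond the scatter).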

Compound 4, half-maximal inhibitory concentration: 2000 nM
Compound 4: the middle estimate sits 23-fold (1.35 log units) above what was measured; measured number outside the range, below it.
By their numbers in this assay, from the lowest: compound 4; then compound 1; then compound 3; then compound 2.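

In this assay, this saturated chain carbon bound to an amide-type nitrogen in a ring accepts 4-fluorophenyl in place of 3-chlorophenyl with a gain, giving a 4.5-fold lower number from compound 1 to compound 4 (0.65 log units; beyond the scatter). So the earlier preference for chloro over fluoro, seen only between compound 2 and compound 3, does not hold for this change. No available evidence explains this result. Because the halogen and its placement change together, the compounds shown cannot separate their contributions. On these data alone, how a 4-chlorophenyl or plain phenyl group would behave at this place remains open.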